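The compounds below may be only part of what the source reports. "The series", "measured", "known", "first", "only" and "open" are said of these compounds alone.

Four compounds share one core: compound 1 `COc1cccc(NC2=CC(=O)c3c(nc4n3[C@H]3OC[C@@H](O)[C@H]3OC4)C2=O)c1`, compound 2 `Cc1ccc(NC2=CC(=O)c3nc4n(c3C2=O)[C@H]2OC[C@@H](O)[C@H]2OC4)cc1C`, compound 3 `O=C1C(Nc2ccccc2)=CC(=O)c2c1nc1n2[C@H]2OC[C@@H](O)[C@H]2OC1` and the unmeasured compound 4 `COc1ccccc1NC1=CC(=O)c2nc3n(c2C1=O)[C@H]1OC[C@@H](O)[C@H]1OC3`; they differ only in the aryl group on the amine nitrogen. Going by the values given here, in a functional assay on HeLa cells (Homo sapiens) for inhibition, read by sulforhodamine B assay (a higher number here means a weaker inhibitor, a lower number a stronger inhibitor), compound 2 gives 2690 nM, the only true number among the three measured. Compound 1 reaches only a limit of this assay, > 8000 nM. Compound 3 likewise reaches only a limit, > 8000 nM. Among the compounds with values here, the single step between measured compounds, a step that the two limits leave unreadable from compound 1 to compound 3, cannot be sized because of the limit of > 8000 nM in this assay, at which 2 of the 3 values shown sit. Compound 2 thus stands alone in yielding a number, and how far its value lies from the limits of compounds 1 and 3 cannot be read.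

The change to compound 4 is 2-methoxyphenyl in place of 3,4-dimethylphenyl on an amine nitrogen. No measured step covers this exchange; the one step shown is unreadable and concerns a different place on the ring. Within the data shown here, the only compound bearing a methoxyphenyl, compound 1, returned a limit, and the limit at the limit of > 8000 nM in this assay, at which 2 of the 3 values shown sit, holds two of the three values, so the expectation for compound 4 is cautious. Compound 4 is expected to come in weaker than compound 2, at an estimated 6000 nM with a range from 2000 nM to 20000 nM. The expected step is a 2.2-fold higher number from compound 2 to compound 4 (0.35 log units; beyond the scatter), with a real chance that this assay reports only a limit.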

Compound 4, half-maximal inhibitory concentration: 2950 nM
For compound 4 the middle estimate is 2.0-fold (0.31 log units) above the measured one, and the stated range covers the measured number.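

In this assay, going by these compounds alone, putting 2-methoxyphenyl in place of 3,4-dimethylphenyl on the amine nitrogen gives a 1.1-fold higher number from compound 2 to compound 4 (0.04 log units; within the scatter), so this is the first readable step at this position, and the two aryl groups cannot be told apart by it. The entering group brings a hydrogen-bond acceptor that the leaving group lacks and swaps a carbon for an oxygen at an equal heavy-atom count, yet the read-out stays within the scatter, so a true number here does not depend on the 3,4-dimethylphenyl group. A methoxy group on the aryl ring therefore does not by itself go with a limit, although compound 1, which also bears a methoxyphenyl, gives only a limit, > 8000 nM.

The steps that involve compounds 1 and 3 still cannot be read, and their distance from the two true numbers stays unknown: the limit of > 8000 nM in this assay, at which 2 of the 4 values shown sit. The compounds shown also leave open how this position would respond to an aryl group carrying an amine or a carboxylic acid, or to a longer alkyl chain in place of the aryl ring.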